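This account rests on a few compounds, and the source may have more. Where it says the series, first, only, none or still open, it means among the compounds named here.

In a functional assay on A-375 cells (Homo sapiens) for activation, with a stated time of 3 days (on this read-out lower numbers stand for an effect already at smaller amounts and higher numbers for an effect only at larger amounts of compound), compound 1 (`O=C(Nc1ccc(-c2cscn2)cc1)C1CCCN(Cc2ccccc2F)C1`) gives 7000 nM. In the same test, compound 2 (`O=C(Nc1ccc(-c2cscn2)cc1)C1CCCN(Cc2cccc(F)c2F)C1`) gives 10000 nM. Within the data shown here, these two numbers lie within the scatter of each other, so compound 2 cannot be told apart from compound 1, the only other compound measured so far.

The next compound, compound 3 (`O=C(Nc1ccc(-c2cscn2)cc1)C1CCCN(Cc2cccnc2)C1`), keeps the shared core but swaps the ring at the end of the molecule: pyridin-3-yl in place of 2,3-difluorophenyl on a saturated chain carbon bound to an amine nitrogen in a ring. The ring of carbon only, with its two fluorines, gives way to a ring holding a hetero atom.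

Among the measured compounds shown here, only one measured step bears on this change: a 1.4-fold higher number from compound 1 to compound 2 (0.15 log units; within the scatter). That step was small, but it only added a fluoro to a ring that stayed in place. For the measured compounds named here, no measurement yet shows what replacing the ring itself does, so it offers only weak guidance. The expected result is a modest shift that stays within the scatter, estimated as a 1.2-fold higher number from compound 2 to compound 3 (0.08 log units; within the scatter), with a wide margin on either side. For compound 3 the estimated value is 12000 nM, with an expected range from 4000 nM to 35000 nM.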

Compound 3, half-maximal effective concentration: > 20000 nM
Compound 3 ended at the assay's limit; the forecaster's own chance of this, stated with the estimate: 25%; middle value at least 1.6-fold (0.22 log units) away from the limit.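

Compound 3 gives no number in this assay, only a limit of the assay: the limit of > 20000 nM in this assay, at which 1 of the 3 values shown sits.

Read against the ring with two fluorines, the change gives an at least 2.0-fold higher number from compound 2 to compound 3 (0.30 log units; that floor lies within the scatter), so this comparison alone does not separate the two compounds, whereas read against the ring with one fluorine it gives an at least 2.8-fold higher number from compound 1 to compound 3 (0.45 log units; beyond the scatter). Among these compounds, the earlier step only added a fluoro to a ring that stayed in place, so this is the first evidence that replacing the ring itself at this place can matter, and here pyridin-3-yl moves the number up, not down.

As far as these compounds go, how far the true value of compound 3 lies past the limit remains unknown, so the full size of both steps stays open. The change also removes the fluorines and brings in a ring nitrogen together, leaving their shares unsettled, and an unsubstituted phenyl, a pyridin-4-yl or a methoxyphenyl at the same place would be needed to tell more.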